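A few compounds are considered here, and "the series" means these few. Any claim that something is new, unique, unknown or untested is made for them only; others in the source may bear on it.

Compound 3 `CC(C)(N)C(=O)N[C@H](COCc1ccccc1)c1nnn(CCCCC#N)n1` is the point of departure. For the measured compounds named here, in a functional assay on H4 cells for agonist activity at growth hormone secretagogue receptor type 1 (Homo sapiens), read by FLIPR (a higher number here means that more compound is needed for the effect, a lower number that less compound is needed), compound 3 gives 1860 nM, the second highest of the three numbers measured so far, and both of its neighbours lie within the usual scatter of it. Compound 1 `CC(C)(N)C(=O)N[C@H](COCc1ccccc1)c1nnn(Cc2ccc(NS(C)(=O)=O)cc2)n1` carries a 4-(methanesulfonamido)phenyl group on the same chain carbon; in this assay compound 1 gives 986 nM. Compound 2 `COC(=O)C(c1ccccc1)n1nnc([C@@H](COCc2ccccc2)NC(=O)C(C)(C)N)n1` bears a methoxycarbonyl)(benzyl group on the aromatic nitrogen; in this assay compound 2 gives 3170 nM. The two steps that connect them to compound 3 were a 1.9-fold higher number from compound 1 to compound 3 (0.28 log units; within the scatter) and a 1.7-fold lower number from compound 2 to compound 3 (0.23 log units; within the scatter), so neither exchange at that position moved the number beyond the scatter.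

Compound 4 `CC(C)(N)C(=O)N[C@H](COCc1ccccc1)c1nnn(CC#N)n1` is the next member. The change from compound 3 reads (cyano in place of 3-cyanopropyl on a saturated chain carbon bound to an aromatic nitrogen). Both measured steps at this position bear on the change, and both were within the scatter, so no step beyond the scatter is expected in this assay in either direction; the account therefore expects the step of a 1.1-fold higher number from compound 3 to compound 4 (0.03 log units; within the scatter). The estimate for compound 4 in this assay is 2000 nM, with a range from 800 nM to 5000 nM.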

Compound 4, half-maximal effective concentration: 1520 nM
Compound 4: middle estimate off by 1.3-fold (0.12 log units), on the high side; low and high end bracket the measured number.
By their numbers in this assay, from the lowest: compounds 1, 4, 3 and 2 (each within the scatter of the next, the first and the last beyond it).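

Cutting 4-cyanobutyl back to cyanomethyl, with the nitrile kept, does not move the number in this assay beyond the scatter (a 1.2-fold lower number from compound 3 to compound 4 (0.09 log units; within the scatter)), so across these two chain lengths the count of saturated chain carbons has no measurable effect. Set against the group of compound 2, cyanomethyl gives the first step at this aromatic nitrogen that lies beyond the scatter (a 2.1-fold lower number from compound 2 to compound 4 (0.32 log units; beyond the scatter)), although it is only a modest one, and the 4-cyanobutyl group of compound 3 stayed within the scatter in the same comparison. Against the aryl group of compound 1 the exchange again stays within the scatter (a 1.5-fold higher number from compound 1 to compound 4 (0.19 log units; within the scatter)), so the small cyano group and the much larger 4-(methanesulfonamido)phenyl group cannot be told apart here. Nothing available explains these numbers.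

From the compounds shown here alone, it remains open whether an amine or a carboxylic acid at the end of the chain, in place of the nitrile, would stay within this narrow band, and whether a longer chain would do so. All four compounds share the rest of their structure, so they say nothing about how the number responds to changes elsewhere in the core.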